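Piperidin-1-yl in Place of Amino on a Carbonyl Carbon

The source may report more compounds than this note shows. Statements on the series, on what has been measured and on what is new or still open speak of the compounds shown alone.

Three compounds share one core: compound 1 (`Cc1ccc2c(c1C)CN(C(C)C)CC2c1ccccc1`), compound 2 (`Cc1ccc2c(c1C)CN(C(N)=O)CC2c1ccccc1`) and compound 3 (`Cc1ccc2c(c1C)CN(C(=O)N1CCCCC1)CC2c1ccccc1`). Among the compounds with values here, in a functional assay on A2780 cells (Homo sapiens) for antiproliferative activity (on this read-out higher numbers stand for weaker inhibition and lower numbers for stronger inhibition), compound 1 gives 6280 nM, the only number available so far. Compound 2 offers no such anchor, as its entry reads "not determined" (no result reported), so it has no place on the scale.

The step of interest starts from compound 2 and makes one structural change to reach compound 3: piperidin-1-yl in place of amino on a carbonyl carbon. Put simply, piperidin-1-yl stands in place of amino on a carbonyl carbon, which can also be read as carbamoyl to (piperidin-1-yl)carbonyl.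

Within the data shown here, no two measured compounds differ in just one place, so the data offer no step to use as a guide. Since compound 2 has no number, this change cannot be sized directly in this assay. The expectation therefore rests on compound 1 at 6280 nM, with no step beyond the usual scatter expected in either direction. For compound 3 the estimated value is 5000 nM, with an expected range from 1500 nM to 20000 nM.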

Compound 3, half-maximal inhibitory concentration: 2830 nM
Beside the measured number, compound 3's estimate is 1.8-fold (0.25 log units) above it; the range from low to high includes it.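

With compound 3, the amine nitrogen in a ring that carries isopropyl in compound 1 is shown to accept a (piperidin-1-yl)carbonyl group with activity retained in this assay. Within the data shown here, the swap gives a 2.2-fold lower number from compound 1 to compound 3 (0.35 log units; beyond the scatter), a modest gain in inhibition that goes beyond the usual scatter, and it is the first step in this set that can be sized. The step named in the title, from amino to piperidin-1-yl on the carbonyl carbon, cannot be read, as compound 2 has no number on this scale, and nothing in hand explains the lower number of compound 3.

The step from compound 1 replaces the whole isopropyl group, so it leaves open how much of the change goes with the carbonyl and how much with the piperidin-1-yl ring. A carbonyl carrying dimethylamino or morpholin-4-yl, or a plain piperidin-1-yl-free chain such as butanoyl, could help separate those two parts and show how much variation this position tolerates.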